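A methylphenyl variant of compound 1 in a cell assay

A few compounds are considered here, and "the series" means these few. Any claim that something is new, unique, unknown or untested is made for them only; others in the source may bear on it.

For the measured compounds named here, compound 1 `CC1(C)[C@H]2CC[C@]1(C)N(Cc1cn(-c3ccccc3Cl)nn1)C(=O)C2` has the higher of the two numbers measured so far: in a functional assay on PANC-1 cells (Homo sapiens) for inhibition, read by MTT assay, with a stated time of 24 h (a lower number here means a stronger inhibitor, a higher number a weaker inhibitor), compound 1 gives 270 nM. Going by the values given here, compound 2 `CC1(C)[C@H]2CC[C@]1(C)N(Cc1cn(-c3cccc(Br)c3)nn1)C(=O)C2` gives 90 nM, and the step of a 3.0-fold lower number from compound 1 to compound 2 (0.48 log units; beyond the scatter) is the only measured change that bears on compound 3, since it also replaces the 2-chlorophenyl on the aromatic nitrogen. Compound 3 `Cc1cccc(-n2cc(CN3C(=O)C[C@@H]4CC[C@@]3(C)C4(C)C)nn2)c1` differs from compound 1 by 3-methylphenyl in place of 2-chlorophenyl on an aromatic nitrogen. Because a 3.0-fold lower number from compound 1 to compound 2 (0.48 log units; beyond the scatter) went modestly toward lower numbers, a similar but smaller shift is expected, a 1.8-fold lower number from compound 1 to compound 3 (0.26 log units; within the scatter). Compound 3 is therefore estimated to give 150 nM, within 60 nM to 400 nM.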

Compound 3, half-maximal inhibitory concentration: 240 nM
Beside the measured number, compound 3's estimate is 1.6-fold (0.20 log units) below it, and the stated range covers the measured number.
By their numbers in this assay, from the lowest: compound 2; then compounds 3 and 1 (each within the scatter of the next).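

In this assay, 3-methylphenyl in place of 2-chlorophenyl gives a 1.1-fold lower number from compound 1 to compound 3 (0.05 log units; within the scatter), so this swap on the aromatic nitrogen leaves the two compounds level. Methyl in place of bromo on the aromatic carbon gives a 2.7-fold higher number from compound 2 to compound 3 (0.43 log units; beyond the scatter), so of these three compounds only compound 2, with its bromo group, stands apart. No evidence is available on the reason for this difference. Open, on these data alone, is whether a 3-chlorophenyl would stay close to compound 2, and how an amine or a carboxylic acid on that phenyl ring would fare.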